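Swapping One Aromatic Ring Group for Another

The source may report more compounds than this note shows. Statements on the series, on what has been measured and on what is new or still open speak of the compounds shown alone.

Measured in a physicochemical assay for solubility, in phosphate buffer, at pH 7.4; on this read-out lower numbers stand for lower solubility and higher numbers for higher solubility:
- compound 1 `OCC1CCN(c2nccnc2OC2CN(c3nc4ccccc4s3)C2)CC1` gives 31000 nM
- compound 2 `CN(C)C1CCN(c2nccnc2OC2CN(c3ccc4ccccc4n3)C2)CC1` gives 500000 nM
- compound 3 `OCc1cccc(-c2nccnc2OC2CN(c3ccc4ccccc4n3)C2)c1` gives 29000 nM

Compound 3 lies within the scatter of compound 1, and both sit far under compound 2. Within the data shown here, the one measured step at this place is large (a 17-fold lower number from compound 2 to compound 3 (1.24 log units; beyond the scatter)), with 3-(hydroxymethyl)phenyl replacing 4-(dimethylamino)piperidin-1-yl. Compound 4 `Cc1ncccc1-c1nccnc1OC1CN(c2ccc3ccccc3n2)C1` has 2-methylpyridin-3-yl in place of 3-(hydroxymethyl)phenyl on an aromatic carbon. Here one six-membered aromatic ring gives way to another, and no measured step shows such a swap, so the large step offers only a weak guide. A small upward move, not beyond the scatter, is expected (a 1.4-fold higher number from compound 3 to compound 4 (0.14 log units; within the scatter)). The estimated value for compound 4 is 40000 nM (range 12000 nM to 130000 nM).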

Compound 4, solubility: 253000 nM
For compound 4 the middle estimate is 6.3-fold (0.80 log units) below the measured one, outside the stated range (above it).
By their numbers in this assay, from the lowest: compounds 3 and 1 (each within the scatter of the next); then compounds 4 and 2 (each within the scatter of the next).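

At this aromatic carbon in this assay, exchanging one six-membered aromatic ring for another is not a neutral change: 2-methylpyridin-3-yl in place of 3-(hydroxymethyl)phenyl gives an 8.7-fold higher number from compound 3 to compound 4 (0.94 log units; beyond the scatter) beyond the scatter. An aromatic ring here can also match 4-(dimethylamino)piperidin-1-yl, with a 2.0-fold lower number from compound 2 to compound 4 (0.30 log units; within the scatter) within the scatter. Nothing measured here explains the difference between the two aromatic groups.

The ring nitrogen, the methyl and the loss of hydroxymethyl all change together, and the compounds shown do not separate them. Plain pyridin-3-yl, without the methyl, would be one group that could begin to do so.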